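A few compounds are considered here, and "the series" means these few. Any claim that something is new, unique, unknown or untested is made for them only; others in the source may bear on it.

Measured set:
Compound 1 `COc1ccc(Nc2ncc3c(n2)N(C2CCCC2)CC(=O)N3C)cc1` gives > 30000 nM in a functional assay on MDA-MB-231 cells (Homo sapiens) for inhibition, read by MTT assay, with a stated time of 48 h (on this read-out lower numbers stand for stronger inhibition and higher numbers for weaker inhibition), a limit of the assay.
Compound 2 `CCN1C(=O)CN(C2CCCC2)c2nc(Nc3ccc(OC)cc3)ncc21` gives > 30000 nM in this assay, a limit of the assay.
Compound 3 `CN1C(=O)CN(C2CCCC2)c2nc(Nc3ccc(N4CCCCC4)cn3)ncc21` gives 29300 nM in this assay.

Compound 2 stands at the limit of the assay in this assay; only compound 3 yields a number, and that one sits close to the same limit (the limit of > 30000 nM in this assay, at which 2 of the 3 values shown sit). Among the compounds with values here, the one step measured directly, a step that the two limits leave unreadable from compound 1 to compound 2, runs between two limits and cannot be read for size.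

Compound 4 `CCN1C(=O)CN(C2CCCC2)c2nc(Nc3ccc(N4CCCCC4)cc3)ncc21` differs from compound 2 by piperidin-1-yl in place of methoxy on an aromatic carbon. Within the data shown here, no measured step covers this change on the shared core. Compound 3 carries the same piperidin-1-yl on a different ring with a methyl on the amide-type nitrogen, and it too ends near the limit (the limit of > 30000 nM in this assay, at which 2 of the 3 values shown sit), so the piperidin-1-yl alone does not take the series off the limit there.

With nothing readable to lean on, the expected step of a number no higher from compound 2 to compound 4 (the limit leaves the size open) from compound 2 to compound 4 is none beyond the scatter. Compound 4 is therefore estimated at 30000 nM in this assay, with a range from 10000 nM to 60000 nM, and a fair chance that only a limit is reported.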

Compound 4, half-maximal inhibitory concentration: > 30000 nM
Compound 4 was reported as a limit; the forecaster's own chance of this, stated with the estimate: 55%; the middle value lies on the limit itself.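

Compound 2 and compound 4 both stand at a limit of this assay, so the exchange of methoxy for piperidin-1-yl gives no step that can be read: the limit of > 30000 nM in this assay, at which 3 of the 4 values shown sit.

The compounds shown leave open what size that exchange has on the shared core, and which change, if any, moves this series clear of the limit.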